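Piperidinyl-thioindole series: benzyl on the ring nitrogen

The compounds below may be only part of what the source reports. "The series", "measured", "known", "first", "only" and "open" are said of these compounds alone.

Measured so far:
compound 1 `Clc1ccc2[nH]cc(SC3CCNCC3)c2c1` — 0.3 mg/kg
compound 2 `Cc1[nH]c2ccc(Cl)cc2c1SC1CCNCC1` — 0.8 mg/kg

Among the measured compounds shown here, in a functional assay on the whole organism with Mus musculus as the target, in the writhing test (on this read-out higher numbers stand for an effect only at larger amounts of compound and lower numbers for an effect already at smaller amounts), compound 1 gives 0.3 mg/kg, the lowest of the two numbers so far; the nearest is compound 2, which in this assay gives 0.8 mg/kg. For the measured compounds named here, the only measured step, a 2.7-fold higher number from compound 1 to compound 2 (0.43 log units; beyond the scatter), concerns methyl in place of hydrogen on an aromatic carbon and is modest.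

Compound 3 `Clc1ccc2[nH]cc(SC3CCN(Cc4ccccc4)CC3)c2c1` differs from compound 1 by benzyl in place of hydrogen on an amine nitrogen in a ring. Going by the values given here, no measured step touches the amine nitrogen in the ring, so the single known step gives no direct guide to this change; it shows only that a small change elsewhere on the shared core moved this assay by a modest amount.

Among the compounds with values here, with no bearing step, a modest rise in number is expected for compound 3, with a wide range: a 3.3-fold higher number from compound 1 to compound 3 (0.52 log units; beyond the scatter). Compound 3 is estimated at 1 mg/kg (range 0.2 mg/kg to 5 mg/kg) in this assay.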

Compound 3, dose for half-maximal effect: 9.7 mg/kg
Compound 3: middle estimate off by 9.7-fold (0.99 log units), on the low side, and the stated range ends below it.
By their numbers in this assay, from the lowest: compound 1; then compound 2; then compound 3.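

In this assay, benzyl in place of hydrogen on the amine nitrogen in the ring gives a 32-fold higher number from compound 1 to compound 3 (1.51 log units; beyond the scatter), a large step. The only earlier step, a 2.7-fold higher number from compound 1 to compound 2 (0.43 log units; beyond the scatter), is modest and lies elsewhere on the shared core, so the amine nitrogen is the first position shown to move this read-out strongly, and here the change works against effect at small doses. No measured information on the compounds accounts for this rise.

On these data alone, with only hydrogen and benzyl compared on this nitrogen, it remains open whether the rise follows from any group placed there or is particular to benzyl; methyl or a phenethyl chain on the same nitrogen would separate these cases. As far as these compounds go, whether the methyl step of compound 2 combines with benzyl also remains open.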